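Bromo for methoxy on the aromatic ring

This account rests on a few compounds, and the source may have more. Where it says the series, first, only, none or still open, it means among the compounds named here.

Compound 1 `COc1cc(C(=O)N2[C@@H](c3nccs3)[C@@H](C(N)=O)C[C@@]2(CC(C)C)C(=O)O)ccc1C(C)(C)C`: 37 mL/min/kg
Compound 2 `COC[C@H]1C[C@@](CC(C)C)(C(=O)O)N(C(=O)c2ccc(C(C)(C)C)c(OC)c2)[C@H]1c1nccs1`: 5 mL/min/kg
Compound 3 `COC[C@@H]1C[C@@](CC(C)C)(C(=O)O)N(C(=O)c2ccc(C(C)(C)C)c(OC)c2)[C@H]1c1nccs1`: 12 mL/min/kg

In an in vivo ADME assay on the whole organism (plasma, strain Sprague-Dawley) for pharmacokinetics, with Rattus norvegicus as the target, at a dose of 1 mg/kg by the intravenous route (a higher number here means faster removal of the compound, a lower number slower removal), compound 1 stands highest of the three at 37 mL/min/kg, clearly above both other compounds, so it is the one removed fastest so far. Compound 4 `CC(C)C[C@@]1(C(=O)O)C[C@H](C(N)=O)[C@H](c2nccs2)N1C(=O)c1ccc(C(C)(C)C)c(Br)c1` keeps the core of compound 1 and alters a single group: bromo in place of methoxy on an aromatic carbon. The change lies on an aromatic carbon, ortho to a tert-butyl group.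

Two measured steps exist, but neither touches that carbon. The first, a 7.4-fold lower number from compound 1 to compound 2 (0.87 log units; beyond the scatter), came with methoxymethyl in place of carbamoyl on a saturated ring carbon. The second, a 2.4-fold higher number from compound 2 to compound 3 (0.38 log units; beyond the scatter), involved a stereocentre at a saturated ring carbon, and its basis is the fact that compounds 2 and 3 differ only in the configuration as drawn. Both show that this assay can shift within this series, but neither gives a size or direction for the aromatic swap. With no measured guide, the expectation stays close to compound 1 at 37 mL/min/kg, with a wide range.

The expected change is a 1.2-fold lower number from compound 1 to compound 4 (0.09 log units; within the scatter), which would be no step beyond the scatter. Compound 4 is estimated at 30 mL/min/kg, with an expected range from 13 mL/min/kg to 65 mL/min/kg.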

Compound 4, clearance: 24 mL/min/kg
Beside the measured number, compound 4's estimate is 1.3-fold (0.10 log units) above it, within the range that was stated.
By their numbers in this assay, from the lowest: compound 2; then compounds 3, 4 and 1 (each within the scatter of the next, the first and the last beyond it).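

In this assay, for the compounds shown here, bromo in place of methoxy on the aromatic carbon ortho to a tert-butyl group gives a 1.5-fold lower number from compound 1 to compound 4 (0.19 log units; within the scatter), the first reading at this position, and it cannot be told apart from no change at all. So although one heavy atom enters where two leave and a hydrogen-bond acceptor is lost, this position has not yet produced a step beyond the scatter, unlike the saturated ring carbon, where methoxymethyl in place of carbamoyl gives a 7.4-fold lower number from compound 1 to compound 2 (0.87 log units; beyond the scatter). Nothing measured here gives a reason for this result.

On these data alone, one swap at one position cannot show how this aromatic carbon behaves in general, so it remains open whether a different group there, such as nitrile or trifluoromethyl, would give a step beyond the scatter. As far as these compounds go, it also remains open whether bromo would give a similar result on the methoxymethyl compounds, compound 2 at 5 mL/min/kg and compound 3 at 12 mL/min/kg, where the removal of the compound is already slower than for compound 1.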